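This account rests on a few compounds, and the source may have more. Where it says the series, first, only, none or still open, it means among the compounds named here.

Working notes on the series. In an assay on isolated protein for displacement of a labelled ligand from melanin-concentrating hormone receptor 1 (Homo sapiens) (on this read-out higher numbers stand for weaker inhibition and lower numbers for stronger inhibition), compound 1 `CCCc1cc(N)c2cc(NC(=O)/C=C/c3ccc(CC)cc3)ccc2n1` gives 1.4 nM, and compound 2 `CCCc1cc(N)c2cc(NC(=O)/C=C/c3ccccc3)ccc2n1` gives 1000 nM. Within the data shown here, compound 2 stands at the highest number of the two measured so far; its nearest neighbour is compound 1, and the step of a 710-fold higher number from compound 1 to compound 2 (2.85 log units; beyond the scatter) separates them. The next compound, compound 3 `CCCc1cc(N)c2cc(NC(=O)/C=C/c3ccc(Cl)cc3Cl)ccc2n1`, is reached from compound 2 by the change (2,4-dichlorophenyl in place of phenyl on a double-bonded chain carbon bound to a double-bonded chain carbon). Among the measured compounds shown here, no measured step carries this exact change. For the measured compounds named here, the one step that bears on it is a 710-fold higher number from compound 1 to compound 2 (2.85 log units; beyond the scatter), which shows that the bare phenyl of compound 2 is far weaker in this assay than a phenyl carrying an ethyl, so a phenyl carrying two chlorines is taken to move back in the same direction, although the size of that return is not fixed by any measured pair and rests on a single comparison. For compound 3 in this assay the expected step is therefore a 130-fold lower number from compound 2 to compound 3 (2.10 log units; beyond the scatter), toward a lower number. Compound 3 is accordingly estimated at 8 nM, with a range from 1.5 nM to 50 nM.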

Compound 3, half-maximal inhibitory concentration: 6.6 nM
The estimate for compound 3 lay 1.2-fold (0.08 log units) above the measured number; measured number inside the range.
By their numbers in this assay, from the lowest: compound 1; then compound 3; then compound 2.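

In this assay, the step of a 150-fold lower number from compound 2 to compound 3 (2.18 log units; beyond the scatter) shows that the return from the bare phenyl on the double-bonded chain carbon does not depend on 4-ethylphenyl, since 2,4-dichlorophenyl, a group of a different kind, also gives a large drop in the number. The two substituted rings are still not interchangeable: the step of a 4.7-fold higher number from compound 1 to compound 3 (0.67 log units; beyond the scatter) is beyond the scatter, which leaves 4-ethylphenyl with the lower number, although this gap is modest beside the distance of either compound from compound 2. No supporting data account for the difference between these rings and phenyl.

The compounds shown do not tell whether both chlorines are needed for the drop or whether one chlorine alone would give it, and they do not separate the effect of where a group sits on the ring from that of which group it is. Also open, as far as these compounds go, is how the number responds to a longer chain such as propyl in place of ethyl, or to an amine or a carboxylic acid on the same ring.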